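This account rests on a few compounds, and the source may have more. Where it says the series, first, only, none or still open, it means among the compounds named here.

Among the measured compounds shown here, compound 1 `COc1ccccc1/C=c1/[nH]c(=O)/c(=C\c2ccccc2OC)n(C)c1=O` is one of three compounds measured in a functional assay on A549 cells (Homo sapiens) for cytotoxicity, read by CCK-8 assay, with a stated time of 72 h (on this read-out higher numbers stand for weaker inhibition and lower numbers for stronger inhibition), where compound 1 gives 7000 nM. The other two carry a different group on the core: compound 2 `C=CCn1c(=O)/c(=C\c2cccc(F)c2)[nH]c(=O)/c1=C\c1ccccc1OC` gives 19700 nM and compound 3 `C=CCn1c(=O)/c(=C\c2cccc(Br)c2)[nH]c(=O)/c1=C\c1ccccc1OC` gives 5400 nM. On these numbers compound 1 sits second highest, close to compound 3 and further from compound 2. Compound 4 `COc1ccccc1/C=c1\c(=O)[nH]/c(=C/c2cccc(Cl)c2Cl)c(=O)n1C` has not yet been measured; it differs from compound 1 in one place: 2,3-dichlorophenyl in place of 2-methoxyphenyl on a double-bonded chain carbon bound to an aromatic carbon. For the measured compounds named here, the only step measured in one place is a 3.6-fold lower number from compound 2 to compound 3 (0.56 log units; beyond the scatter), a swap of one halogen for another on an aromatic carbon, made on compounds that also differ from compound 1 elsewhere, so it bears on the change to compound 4 only loosely. It does point toward halogen-bearing rings giving lower numbers. A modest step down is therefore expected, a 1.8-fold lower number from compound 1 to compound 4 (0.24 log units; within the scatter), with compound 4 estimated at 4000 nM, plausibly between 1500 nM and 11000 nM.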

Compound 4, half-maximal inhibitory concentration: 200 nM
Compound 4: middle estimate off by 20-fold (1.30 log units), on the high side; the whole stated range lies above it.
By their numbers in this assay, from the lowest: compound 4; then compounds 3 and 1 (each within the scatter of the next); then compound 2.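

In this assay the exchange of 2-methoxyphenyl for 2,3-dichlorophenyl on a double-bonded chain carbon bound to an aromatic carbon gives a 35-fold lower number from compound 1 to compound 4 (1.54 log units; beyond the scatter) and marks this place as highly sensitive to the ring it carries. The earlier compounds shown here showed only one halogen replaced by another on an aromatic carbon, whereas this pair shows that changing the ring's substituents can, with the rest of compound 1 unchanged, produce a large step on its own. No supporting data are available to explain this step.

The change removes a methoxy group and adds two chlorine atoms together, so the compounds shown do not separate the part each plays. A phenyl ring with a single chlorine, or one bearing a trifluoromethyl group or a nitrile, would test how specific the 2,3-dichlorophenyl group is.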